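The source may report more compounds than this note shows. Statements on the series, on what has been measured and on what is new or still open speak of the compounds shown alone.

Measured compounds in a functional assay on HeLa cells (Homo sapiens) for antiproliferative activity, with a stated time of 24 h; on this read-out higher numbers stand for weaker inhibition and lower numbers for stronger inhibition:

- compound 1, `NC(=O)c1c(NC(=O)c2ccccc2Cl)sc2c1CCN(Cc1ccc([N+](=O)[O-])cc1)C2` — compound 1 gives 46100 nM
- compound 2, `NC(=O)c1c(NC(=O)c2cccc([N+](=O)[O-])c2)sc2c1CCN(Cc1ccc(Cl)cc1Cl)C2` — compound 2 gives 33000 nM
- compound 3, `NC(=O)c1c(NC(=O)c2ccccc2Cl)sc2c1CCN(C(=S)Nc1cc(C(F)(F)F)cc(C(F)(F)F)c1)C2` — compound 3 gives 48900 nM

All three measured members of the series sit close together on this read-out. Compound 1 has the second highest of the three numbers; its nearest neighbour is compound 3, whose number is only slightly higher, and its furthest is compound 2, whose number is somewhat lower, yet both of these gaps fall within the usual scatter of repeated measurements, so no order among the three can be claimed.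

The next compound to be examined is compound 4, `NC(=O)c1c(NC(=O)c2ccccc2Cl)sc2c1CCN(C(=S)Nc1cccnc1)C2`. It is compared with compound 1, from which it differs in one place: a group of 9 heavy atoms (6 carbon, 2 nitrogen, 1 sulfur; one six-membered aromatic ring with 1 hetero atom) in place of a group of 10 heavy atoms (7 carbon, 1 nitrogen, 2 oxygen; one six-membered aromatic ring of carbon only), on an amine nitrogen in a ring

For the measured compounds named here, no step between measured compounds is available to calibrate this change. What can be said is that compound 3, which carries the same shared core and an acylthiourea-type substituent on the same ring nitrogen, lands within the scatter of compound 1. On that basis no movement beyond the scatter is expected from compound 1 to compound 4, and the step is estimated at a 1.0-fold lower number from compound 1 to compound 4 (0.01 log units; within the scatter) in this assay.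

Compound 4 is therefore expected to give about 45000 nM in this assay, with a plausible range from 20000 nM to 100000 nM.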

Compound 4, half-maximal inhibitory concentration: > 50000 nM
Compound 4: only a limit was reported; the forecaster's own chance of this, stated with the estimate: 25%; at least 1.1-fold (0.04 log units) between middle value and limit.
By their numbers in this assay, from the lowest: compounds 2, 1 and 3 (each within the scatter of the next). At a limit, above all of these: compound 4.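

In this assay, compound 4 carries only a limit of the assay, > 50000 nM, and not a number. Exchanging the 4-nitrobenzyl group on the amine nitrogen in a ring for the thiocarbonyl-linked group with its six-membered aromatic ring with 1 hetero atom gives an at least 1.0-fold higher number from compound 1 to compound 4 (0.03 log units; that floor lies within the scatter); as that floor lies within the scatter, the change is not shown to weaken inhibition, but it brings no sign of stronger inhibition either. The step can be read only as a floor because the value of compound 4 stops at the limit, which also marks the top of what this series can show on this read-out: the limit of > 50000 nM in this assay, at which 1 of the 4 values shown sits.

As far as these compounds go, how far compound 4 lies beyond the limit stays open, and so does whether this position can carry any change that moves the number beyond the scatter in either direction. Also open, from the compounds shown here alone, is what a plain benzyl group, or a saturated amine such as morpholine attached through the same thiocarbonyl, would give on the shared core.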